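The source may report more compounds than this note shows. Statements on the series, on what has been measured and on what is new or still open speak of the compounds shown alone.

Compound 1 `CC(C)[C@H](NC(=O)COc1cccc2ccccc12)C(=O)N[C@@H](CC(=O)O)C(=O)CSc1nncn1C`: in a functional assay on Jurkat cells (Homo sapiens) for inhibition (on this read-out lower numbers stand for stronger inhibition and higher numbers for weaker inhibition), compound 1 gives only a limit, > 200000 nM.
Compound 2 `CC(C)[C@H](NC(=O)COc1cccc2ccccc12)C(=O)N[C@@H](CC(=O)O)C(=O)CSc1nc2ccccc2[nH]1`: in this assay compound 2 gives only a limit, > 200000 nM.

Compound 1 thus stands at the limit of > 200000 nM in this assay, at which 2 of the 2 values shown sit, and compound 2 stands at that same limit, so neither compound has a number of its own. Among the compounds with values here, the only measured step, a step that the two limits leave unreadable from compound 1 to compound 2, cannot be read, and no further pair is available. Compound 3 `CC(C)[C@H](NC(=O)COc1cccc2ccccc12)C(=O)N[C@@H](CC(=O)O)C(=O)COc1nncc(Cl)c1Cl` differs from compound 1 by (4,5-dichloropyridazin-3-yl)oxy in place of (4-methyl-4H-1,2,4-triazol-3-yl)sulfanyl on a saturated chain carbon bound to a carbonyl carbon. Within the data shown here, no measured step touches this change: the step to compound 2 swaps one ring on the sulfur, whereas here the sulfur itself leaves together with its ring. The measurements therefore leave both the direction and the size of the coming step open. Compound 3 is expected to lie near 50000 nM, within 3000 nM to 200000 nM, an expected step of an at least 4.0-fold lower number from compound 1 to compound 3 (0.60 log units; beyond the scatter), with a real chance that only a limit is again reported.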

Compound 3, half-maximal inhibitory concentration: > 200000 nM
Compound 3 gave a limit, no number; the forecaster's own chance of this, stated with the estimate: 40%; middle value at least 4.0-fold (0.60 log units) away from the limit.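

Compound 3 also gives only a limit in this assay, so its steps from compound 1 and from compound 2 cannot be read, and all three compounds share one limit: the limit of > 200000 nM in this assay, at which 3 of the 3 values shown sit. The compounds shown leave open how far any of them lies beyond that limit, and whether either swap changes inhibition at all.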